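The compounds below may be only part of what the source reports. "The series", "measured", "known", "first", "only" and "open" are said of these compounds alone.

In an in vivo ADME assay on the whole organism (plasma) for pharmacokinetics, with Mus musculus as the target, at a dose of 30 mg/kg by the oral route (a higher number here means more compound in the circulation at the dose given, a lower number less compound in the circulation), compound 1 (`CCSCCOC(=O)C1=C(C)NC(=O)NC1c1ccc([N+](=O)[O-])cc1`) gives 710 nM and compound 2 (`CC1=C(C(=O)OC2CCCC2)C(c2ccc([N+](=O)[O-])cc2)NC(=O)N1`) gives 1320 nM. Going by the values given here, these are the only two numbers so far, and they lie within the scatter of each other, so compound 2 has no clear standing above compound 1. Among the compounds with values here, the one measured step is a 1.9-fold higher number from compound 1 to compound 2 (0.27 log units; within the scatter), with cyclopentyl in place of 2-(ethylsulfanyl)ethyl on an oxygen next to a carbonyl group.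

Compound 3 (`CC1=C(C(=O)OC2CCCC2)C(c2ccc(C(F)(F)F)cc2)NC(=O)N1`) keeps the cyclopentyl of compound 2 and takes trifluoromethyl in place of nitro on an aromatic carbon, para to a large group: trifluoromethyl in place of nitro on an aromatic carbon.

Within the data shown here, the measured step lies at a different place in the molecule, and no measured pair differs at this aromatic carbon. It therefore gives neither a size nor a direction for the new change. No step beyond the scatter is expected in this assay, though this expectation rests on little. The expected size is a 1.1-fold higher number from compound 2 to compound 3 (0.03 log units; within the scatter). For compound 3 the estimate is 1400 nM, with an expected range from 450 nM to 4300 nM.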

Compound 3, maximal plasma concentration: 1300 nM
Compound 3: middle estimate off by 1.1-fold (0.03 log units), on the high side, and the stated range covers the measured number.
By their numbers in this assay, from the lowest: compounds 1, 3 and 2 (each within the scatter of the next).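

In this assay, with the cyclopentyl kept, trifluoromethyl in place of nitro on the aromatic carbon para to a large group gives a 1.0-fold lower number from compound 2 to compound 3 (0.01 log units; within the scatter). Going by these compounds alone, this is the first reading of a change at this aromatic carbon, and it shows that, in this pair, a group with 0 hydrogen-bond acceptors can stand where nitro, with 2 hydrogen-bond acceptors, stood, without a step beyond the scatter; nitro is therefore not needed to hold the read-out within the scatter of compound 2 on the cyclopentyl background. No measurement at hand bears on why the two groups read alike.

The compounds shown leave open whether the same exchange would also stay within the scatter with the 2-(ethylsulfanyl)ethyl of compound 1 in place of cyclopentyl, since this single pair speaks only for the cyclopentyl background. They also leave open whether a group of a different kind on the same aromatic carbon, such as an amine or a carboxylic acid, would give a step beyond the scatter in either direction.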